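Swapping a bromophenyl for methyl on the alcohol carbon

This account rests on a few compounds, and the source may have more. Where it says the series, first, only, none or still open, it means among the compounds named here.

Measured compounds:
compound 1 `COc1cccc(C(O)CCn2nc3c(Br)c(Br)c(Br)c(Br)c3n2)c1` – 71%
compound 2 `C[C@@H](O)CCn1nc2c(Br)c(Br)c(Br)c(Br)c2n1` – 105%
compound 3 `OC(CCn1nc2c(Br)c(Br)c(Br)c(Br)c2n1)c1ccc(Br)cc1` – 59%

In a functional assay on MCF7 cells (Homo sapiens) for antiproliferative activity, read by MTT assay, with a stated time of 24 h, tested at 25 uM (a lower number here means a stronger effect, a higher number a weaker effect of the compound at the concentration tested), compound 3 gives the lowest of the three numbers, so it shows the strongest effect here. Compound 1 stands nearest to it and compound 2 furthest; the step of a number 12 percentage points lower from compound 1 to compound 3 (beyond the scatter) is beyond the scatter, as is the gap to compound 2.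

Compound 4 `CC(O)CCn1nc2c(Br)c(Br)c(Br)c(Br)c2n1` has not yet been tested. It differs from compound 3 by methyl in place of 4-bromophenyl on a saturated chain carbon bound to an oxygen on a saturated carbon and a saturated chain carbon. Going by the values given here, only one measured step changes the same position, namely the move from compound 1 to compound 3, and it exchanged one aromatic ring for another, which is not the kind of change made here. Compound 2, however, already carries a methyl on a saturated chain carbon bound to an oxygen on a saturated carbon and a saturated chain carbon, differing from compound 4 only in that its stereochemistry is specified, and compound 2 gives 105%. Compound 4 is therefore expected to land close to compound 2, a large upward step a number 41 percentage points higher from compound 3 to compound 4 (beyond the scatter) toward a weaker effect. The estimate for compound 4 is 100%, between 85% and 115%.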

Compound 4, a percentage reported as activity, at one concentration (the size of the read-out at that concentration, not a potency): 102%
Compound 4: the middle estimate sits 2 percentage points below what was measured, and the stated range covers the measured number.
By their numbers in this assay, from the lowest: compound 3; then compound 1; then compounds 4 and 2 (each within the scatter of the next).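

In this assay, an aromatic ring at this position goes with a clear effect that methyl does not match: methyl in place of 4-bromophenyl gives a number 43 percentage points higher from compound 3 to compound 4 (beyond the scatter), and methyl in place of 3-methoxyphenyl gives a number 31 percentage points higher from compound 1 to compound 4 (beyond the scatter). Going by these compounds alone, the earlier step exchanged only one aromatic ring for another, so these are the first steps to show how much rides on having a ring here at all. The two methyl compounds cannot be separated, with a number 3 percentage points lower from compound 2 to compound 4 (within the scatter), and that comparison rests on a single feature: the fact that one of compounds 2 and 4 is drawn with a defined configuration and the other without, at the place where they differ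

As far as these compounds go, whether a cyclohexyl ring or a longer chain such as butyl would behave like the aromatic rings or like methyl remains open. The compounds shown therefore cannot say whether the aromatic ring itself or simply a larger group goes with the stronger effect.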